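A few compounds are considered here, and "the series" means these few. Any claim that something is new, unique, unknown or untested is made for them only; others in the source may bear on it.

Measured compounds:
- Compound 1 `CN(C)C(=O)c1cc2cnc(Nc3ccc(NC(=O)C4(C(=O)Nc5ccccc5)CC4)cc3)nc2n1C1CCCC1`: 52.8%
- Compound 2 `CN(C)C(=O)c1cc2cnc(Nc3ccc(NC(=O)C4(C(=O)Nc5ccccc5F)CC4)cc3)nc2n1C1CCCC1`: 85.2%
- Compound 3 `CN(C)C(=O)c1cc2cnc(Nc3ccc(NC(=O)C4(C(=O)Nc5ccc(F)cc5)CC4)cc3F)nc2n1C1CCCC1`: 6.3%

These three share one core and were tested in a functional assay on T47D cells (Homo sapiens) for inhibition, read by CCK-8 assay, with a stated time of 72 h, tested at 1 uM; a higher number here means more inhibition of growth at the concentration tested, a lower number less inhibition of growth. Compound 2 stands highest of the three; compound 1 sits well below it, and compound 3 sits far below both.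

Among the measured compounds shown here, only one single-place step is available here: a number 32.4 percentage points higher from compound 1 to compound 2 (beyond the scatter). Compound 3 differs from compound 2 in more than one place, so its low number cannot be tied to any one change.

Compound 4 `CN(C)C(=O)c1cc2cnc(Nc3ccc(NC(=O)C4(C(=O)Nc5ccc(Cl)c(C(F)(F)F)c5)CC4)cc3)nc2n1C1CCCC1` is not yet measured. It differs from compound 2 in one place: 4-chloro-3-(trifluoromethyl)phenyl in place of 2-fluorophenyl on an amide-type nitrogen. The measured step from compound 1 to compound 2 concerns only the gain of a fluorine on that ring, not a change in its pattern of substituents, so it bears on the present step only loosely. Compound 3, which also carries a different pattern on that ring, gave a far lower number. A drop in this assay is therefore expected, though with wide uncertainty, the estimated step being a number 30.2 percentage points lower from compound 2 to compound 4 (beyond the scatter). Compound 4 is estimated at 55%, within a range of 20% to 85%.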

Compound 4, percent growth inhibition at one concentration: 6.9%
Compound 4: middle estimate off by 48.1 percentage points, on the high side; the whole stated range lies above it.
By their numbers in this assay, from the lowest: compounds 3 and 4 (each within the scatter of the next); then compound 1; then compound 2.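

In this assay putting 4-chloro-3-(trifluoromethyl)phenyl in place of 2-fluorophenyl on the amide-type nitrogen gives a number 78.3 percentage points lower from compound 2 to compound 4 (beyond the scatter) and wipes out the gain that fluoro had brought, while the same group in place of plain phenyl also loses ground (a number 45.9 percentage points lower from compound 1 to compound 4 (beyond the scatter)). This position therefore does not simply reward any halogen on the ring: among compounds 1, 2 and 4, one change raises the number and the other lowers it well under the unsubstituted phenyl. Nothing available explains why this larger ring, with 11 heavy atoms against 7, does so poorly.

Chloro and trifluoromethyl enter together, so which of them carries the drop cannot be told. Going by these compounds, how a ring carrying a methoxy group or a nitrile would read at this position also stays open.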